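Phenyl for methyl on the ring nitrogen of compound 2

The compounds below may be only part of what the source reports. "The series", "measured", "known", "first", "only" and "open" are said of these compounds alone.

Three compounds in this set have a number in a functional assay on MCF7 cells (Homo sapiens) for antiproliferative activity, tested at 1 uM; on this read-out lower numbers stand for less inhibition and higher numbers for more inhibition at the one concentration tested (going by the name of the read-out). Compound 2 `CCOC(=O)c1ccc(CO/N=C/c2c(C)nn(C)c2Oc2ccc(Cl)cc2)cc1` gives 33.9%, which is the highest of the three; compound 3 `Cc1nn(C)c(Oc2ccc(Cl)cc2)c1/C=N/OCc1ccc([N+](=O)[O-])cc1` gives 27.1%, and the step of a number 6.8 percentage points lower from compound 2 to compound 3 (within the scatter) is within the scatter, so the two stand level. Compound 1 `Cc1nn(-c2ccccc2)c(Oc2ccc(Cl)cc2)c1/C=N/OCc1ccc(C(=O)OC(C)(C)C)cc1` gives -8.4%, a number far below compound 2 and beyond the scatter.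

The compound now in question is compound 4 `CCOC(=O)c1ccc(CO/N=C/c2c(C)nn(-c3ccccc3)c2Oc2ccc(Cl)cc2)cc1`. It keeps the ethoxycarbonyl of compound 2 and changes only the group on the ring nitrogen: phenyl in place of methyl on an aromatic nitrogen.

Among the compounds with values here, no measured step changes exactly this one place. The nearest guide is the pair compound 1 and compound 2, which differ in the ring-nitrogen group and in the ester at once; there, the phenyl-bearing compound 1 sits far lower than the methyl-bearing compound 2. With the ester change between compound 2 and compound 3 being within the scatter, most of that gap is read as coming with the phenyl. Compound 4 is therefore expected to fall, with an estimated step of a number 31.9 percentage points lower from compound 2 to compound 4 (beyond the scatter) in this assay, landing near compound 1. The estimate for compound 4 is 2%, with a range from -15% to 22%.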

Compound 4, a percentage reported as inhibition, at one concentration (the size of the read-out at that concentration, not a potency): 12%
The estimate for compound 4 lay 10 percentage points below the measured number, within the range that was stated.
By their numbers in this assay, from the lowest: compound 1; then compound 4; then compounds 3 and 2 (each within the scatter of the next).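

In this assay, the aromatic nitrogen now has a single-change comparison with the ethoxycarbonyl held constant: the step of a number 21.9 percentage points lower from compound 2 to compound 4 (beyond the scatter) shows that phenyl in place of methyl lowers inhibition at this position. The ester is also shown to count with phenyl on that nitrogen, as ethyl in place of tert-butyl on the oxygen next to the carbonyl group gives the step of a number 20.4 percentage points higher from compound 1 to compound 4 (beyond the scatter) and so separates the ester change from the nitrogen substituent. Nothing available explains either step.

The series does not show whether the number at the aromatic nitrogen falls gradually between methyl and phenyl, or how an ethyl group, a longer chain or a benzyl group would behave there. It also leaves open whether tert-butyl in place of ethyl would lower the number with methyl on the nitrogen as it does with phenyl, and how a carboxylic acid or an amide in place of the ester would read in this assay with either nitrogen substituent.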